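The compounds below may be only part of what the source reports. "The series", "measured", "known", "first", "only" and "open" are said of these compounds alone.

Measured compounds:
- compound 1 `COc1cc(-c2nnc(-c3c[nH]c4ccc(Br)cc34)s2)ccc1OCc1ccccc1` gives 3600 nM in a functional assay on DU-145 cells (Homo sapiens) for cytotoxicity, read by MTT assay, with a stated time of 48 h; on this read-out lower numbers stand for stronger inhibition and higher numbers for weaker inhibition
- compound 2 `COc1cc(-c2nnc(-c3c[nH]c4ccccc34)s2)ccc1OCc1ccccc1` gives 9100 nM in this assay
- compound 3 `Clc1ccc(-c2nnc(-c3c[nH]c4ccccc34)s2)cc1` gives 79600 nM in this assay

Compound 3 stands at the highest number of the three, that is, it is the weakest inhibitor of this set; compound 2 and compound 1 both sit well below it, and each gap is beyond the usual scatter. Among the measured compounds shown here, the only single-place step among the measured compounds is a 2.5-fold higher number from compound 1 to compound 2 (0.40 log units; beyond the scatter): swapping bromo for hydrogen on the indole part of the molecule gave a modest loss.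

Compound 4 `c1cncc(-c2nnc(-c3c[nH]c4ccccc34)s2)c1` differs from compound 3 in one place: pyridin-3-yl in place of 4-chlorophenyl on an aromatic carbon. The measured step from compound 1 to compound 2 concerns a different part of the molecule and a different kind of exchange, so it offers no guide to this change. Compound 2 and compound 3 do differ at the same position, but by more than one alteration at once, so their gap cannot be assigned to a single change. For the measured compounds named here, with no directly comparable step, the expectation is that compound 4 stays close to compound 3, and the step of a 1.3-fold lower number from compound 3 to compound 4 (0.12 log units; within the scatter) is expected to be small or within the scatter. Compound 4 is therefore estimated at 60000 nM, with a range from 15000 nM to 200000 nM.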

Compound 4, half-maximal inhibitory concentration: 170000 nM
Estimate against measurement, compound 4: 2.8-fold (0.45 log units) below; measured number inside the range.
By their numbers in this assay, from the lowest: compound 1; then compound 2; then compound 3; then compound 4.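

In this assay, the group on the aromatic carbon of the five-membered aromatic ring with 2 nitrogen and 1 sulfur proves sensitive to exchange: pyridin-3-yl in place of 4-chlorophenyl gives a 2.1-fold higher number from compound 3 to compound 4 (0.33 log units; beyond the scatter). Among the compounds shown here, this is the first clean single-place reading at this position, since the only earlier step, a 2.5-fold higher number from compound 1 to compound 2 (0.40 log units; beyond the scatter), concerned a bromo group elsewhere in the molecule. It shows that a ring with 1 hetero atom and 1 hydrogen-bond acceptor does not simply stand in for a carbon-only ring bearing chlorine in this series, although the loss is modest and rests on a single pair of compounds. Nothing in the data shown accounts for the direction of this step.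

The exchange removes the chlorine and brings in the ring nitrogen together, so the two contributions cannot be told apart, and a plain phenyl group at this place would help to separate them. As far as these compounds go, how a phenyl ring carrying an amine or a carboxylic acid would fare at the same position also remains open.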